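The source may hold more compounds than are shown below. What is called first, only, known or untested is meant among the compounds shown, and "the series" means these compounds.

Working notes on the series built on the shared core of compound 1 `CC(C)N(Cc1cccc(OCCCCCC(=O)O)c1)C(=O)c1ccccc1`, which carries hydrogen at the varied aromatic carbon. In an ADME assay on BJ cells (Homo sapiens) for cytotoxicity, read by CellTiter-Glo and resazurin assay, with a stated time of 72 h (on this read-out lower numbers stand for an effect already at smaller amounts and higher numbers for an effect only at larger amounts of compound), compound 1 gives > 26000 nM, a limit of the assay. Compound 2 `CC(C)N(Cc1cccc(OCCCCCC(=O)O)c1)C(=O)c1ccc(-c2cccc3ccccc23)cc1` carries naphthalen-1-yl at that carbon. In this assay compound 2 gives < 1.3 nM, again a limit. Compound 3 `CC(C)N(Cc1cccc(OCCCCCC(=O)O)c1)C(=O)c1ccc(-c2ccsc2)cc1` carries thiophen-3-yl there. In this assay compound 3 gives > 26000 nM, also a limit. Compound 3 thus stands at the high end of the numbers shown, at the same limit as compound 1. The steps of an at least 20000-fold lower number from compound 1 to compound 2 (4.30 log units; beyond the scatter) and an at least 20000-fold higher number from compound 2 to compound 3 (4.30 log units; beyond the scatter) are read only between limits; their stated sizes rest on the limit of < 1.3 nM in this assay, at which 1 of the 3 values shown sits, and (the limit of > 26000 nM in this assay, at which 2 of the 3 values shown sit). The step that the two limits leave unreadable from compound 1 to compound 3 cannot be sized. Compound 4 `CC(C)N(Cc1cccc(OCCCCCC(=O)O)c1)C(=O)c1ccc(-c2ccc3cc[nH]c3c2)cc1` differs from compound 3 by 1H-indol-6-yl in place of thiophen-3-yl on an aromatic carbon, so a second fused ring enters, as in compound 2. The step of an at least 20000-fold higher number from compound 2 to compound 3 (4.30 log units; beyond the scatter) bears most on this, and a large move toward lower numbers in this assay is expected, though with wide uncertainty. The estimated step is an at least 86-fold lower number from compound 3 to compound 4 (1.93 log units; beyond the scatter). Compound 4 is expected to give 300 nM, between 3 nM and 26000 nM.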

Compound 4, half-maximal effective concentration: > 26000 nM
Compound 4: no number, only a limit (the forecaster's own chance of this, stated with the estimate: 35%); middle value at least 86-fold (1.93 log units) from the limit.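

In this assay the change from naphthalen-1-yl to 1H-indol-6-yl on this aromatic carbon, para to a large group, is an at least 20000-fold higher number from compound 2 to compound 4 (4.30 log units; beyond the scatter) and shows that a second fused ring here is not enough for a low number. The steps to compound 4 from compound 1 and from compound 3 join two limits and cannot be read. Within the data shown here, the size of the one readable step rests on a limit at each end: the limit of < 1.3 nM in this assay, at which 1 of the 4 values shown sits, and (the limit of > 26000 nM in this assay, at which 3 of the 4 values shown sit).

On these data alone, it stays open whether the limit reached by compound 4 goes with the ring nitrogen or with the point of attachment of the fused rings. Naphthalen-2-yl and 1H-indol-4-yl at this carbon would bear on that question.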